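The source may hold more compounds than are shown below. What is called first, only, known or untested is meant among the compounds shown, and "the series" means these compounds.

Compounds measured so far in an assay on cells for agonist activity at ecdysone receptor (Bombyx mori), read by a luciferase reporter, with a stated time of 24 h; a lower number here means that less compound is needed, a higher number that more compound is needed for the effect:
compound 1, `CCc1ccc(C(=O)NN(C(=O)c2ccccc2Cl)C(C)(C)C)cc1`, gives 5.75 nM
compound 2, `CCCCCCC(=O)N(NC(=O)c1ccc(CC)cc1)C(C)(C)C`, gives 11700 nM

Compound 2 stands highest of the two numbers; its nearest neighbour is compound 1, and the step of a 2000-fold higher number from compound 1 to compound 2 (3.31 log units; beyond the scatter) shows how much a hexyl chain in place of the 2-chlorophenyl group raised the number. Compound 3, `CCc1ccc(C(=O)NN(C(=O)C2CC=CCC2)C(C)(C)C)cc1`, differs from compound 2 by cyclohex-3-en-1-yl in place of hexyl on a carbonyl carbon. Among the compounds with values here, only that single step bears on this change, and it was large. Within the data shown here, since a ring enters again, a move back toward lower numbers is expected, though the ring is not aromatic like the one in compound 1. Compound 3 is therefore estimated at 400 nM, within 50 nM to 3000 nM, expected as a 29-fold lower number from compound 2 to compound 3 (1.47 log units; beyond the scatter).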

Compound 3, half-maximal effective concentration: 1000 nM
Estimate against measurement, compound 3: 2.5-fold (0.40 log units) below; the range from low to high includes it.
By their numbers in this assay, from the lowest: compound 1; then compound 3; then compound 2.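

In this assay, tying the six carbons of hexyl into cyclohex-3-en-1-yl on this carbonyl carbon recovers only part of the ground lost with the chain, giving a 12-fold lower number from compound 2 to compound 3 (1.07 log units; beyond the scatter). The same ring still falls well short of 2-chlorophenyl, with a 170-fold higher number from compound 1 to compound 3 (2.24 log units; beyond the scatter), so among these compounds having a ring at this place does not alone match compound 1. Nothing available explains either step. Going by these compounds, it remains open whether cyclohexyl, without the double bond, would behave like cyclohex-3-en-1-yl, and where plain phenyl would fall between these groups.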